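A few compounds are considered here, and "the series" means these few. Any claim that something is new, unique, unknown or untested is made for them only; others in the source may bear on it.

Measured in a functional assay on MDA-MB-231 cells (Homo sapiens) for antiproliferative activity, read by MTT assay, with a stated time of 48 h; on this read-out higher numbers stand for weaker inhibition and lower numbers for stronger inhibition:

compound 1 `Cc1cnc(Nc2ccc(S(C)(=O)=O)cc2)nc1Nc1nc2ccccc2s1`, 14800 nM
compound 2 `Cc1cnc(Nc2ccc(S(N)(=O)=O)cc2)nc1Nc1nc2ccccc2s1`, 16800 nM
compound 3 `COc1ccc2nc(Nc3ccnc(Nc4ccc(S(N)(=O)=O)cc4)n3)sc2c1`, 6240 nM

Compound 1 and compound 2 share one core and differ only by methyl in place of amino on a sulfonyl sulfur; that step is a 1.1-fold lower number from compound 2 to compound 1 (0.06 log units; within the scatter). Compound 3 carries another core; how its core differs from that of compound 2 is not broken down here. In this assay compound 3 has the lowest of the three numbers, and the gaps to compound 1 and compound 2 lie beyond the scatter.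

Compound 4 `COc1ccc2nc(Nc3ccnc(Nc4ccc(S(C)(=O)=O)cc4)n3)sc2c1` has not yet been measured. It differs from compound 3 by methyl in place of amino on a sulfonyl sulfur, the same change seen between compound 2 and compound 1. Because that earlier step was a 1.1-fold lower number from compound 2 to compound 1 (0.06 log units; within the scatter), the estimate for compound 4 in this assay is 5600 nM, between 2600 nM and 12000 nM. The step this estimate implies is a 1.1-fold lower number from compound 3 to compound 4 (0.05 log units; within the scatter), expected to stay within the scatter.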

Compound 4, half-maximal inhibitory concentration: 32700 nM
Compound 4: the middle estimate sits 5.8-fold (0.77 log units) below what was measured, outside the stated range (above it).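

In this assay, the change from sulfamoyl to methylsulfonyl gives a 5.2-fold higher number from compound 3 to compound 4 (0.72 log units; beyond the scatter) on this core, so the result from the other core did not carry over. Set side by side, the two steps show that the size of this change depends on the core in this series: the same change on two cores in this assay, a 1.1-fold lower number (0.06 log units; within the scatter) from compound 2 to compound 1 and a 5.2-fold higher number (0.72 log units; beyond the scatter) from compound 3 to compound 4, 5.9-fold (0.77 log units) apart, beyond the scatter of two such steps. Among these compounds, they do not show which part of the cores accounts for the gap, and each core contributes only a single pair.

On these data alone, what an ethyl or a dimethylamino group on the sulfonyl sulfur would do on either core stays open. So does whether a third core would behave like the core of compound 1 or like the core of compound 3.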